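A few compounds are considered here, and "the series" means these few. Any claim that something is new, unique, unknown or untested is made for them only; others in the source may bear on it.

In an ADME assay on RPTEC cells (Homo sapiens) for cytotoxicity, read by resazurin assay, with a stated time of 4 days (on this read-out higher numbers stand for lower toxicity in this test and lower numbers for higher toxicity in this test), compound 1 `Cc1nc2ccccc2n1-c1ccc(C(=O)NC2CC2)s1` gives > 62000 nM, which is a limit of the assay and not a number. Compound 2 `CCc1nc2ccccc2n1-c1ccc(C(=O)NC2CC2)s1` gives > 62000 nM, which is also a limit, so its standing is known only as a limit. Compound 3 `CCCc1nc2ccccc2n1-c1ccc(C(=O)NC2CC2)s1` differs from compound 2 by one change, (methyl in place of hydrogen on a saturated chain carbon, two bonds along the chain from an aromatic carbon), in words methyl in place of hydrogen on a saturated chain carbon, two bonds along the chain from an aromatic carbon, or ethyl to propyl. The closest measured step is a step that the two limits leave unreadable from compound 1 to compound 2, so it offers no size to carry over. Compound 1 and compound 2 both sit at the limit of > 62000 nM in this assay, at which 2 of the 2 values shown sit, so no step beyond the scatter is expected in this assay, in either direction. The expected step is a number no higher from compound 2 to compound 3 (the limit leaves the size open). For compound 3 the estimated value is 62000 nM, with an expected range from 30000 nM to 120000 nM.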

Compound 3, concentration lethal to 50% of the cells: > 62000 nM
Compound 3 ended at the assay's limit; the forecaster's own chance of this, stated with the estimate: 80%; the middle value lies on the limit itself.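

No step can be read among compound 1, compound 2 and compound 3, as each result is a limit of the assay and not a number: the limit of > 62000 nM in this assay, at which 3 of the 3 values shown sit.

The compounds shown leave open whether going from methyl through ethyl to propyl moves the read-out in this assay at all.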